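Isoquinolinyl for quinolinyl on the sulfonyl of compound 3

A few compounds are considered here, and "the series" means these few. Any claim that something is new, unique, unknown or untested is made for them only; others in the source may bear on it.

Measured in an assay on HEK293 cells for displacement of a labelled ligand from 5-hydroxytryptamine receptor 6 (Homo sapiens), read by scintillation counting; a lower number here means a stronger inhibitor, a higher number a weaker inhibitor:
compound 1 `O=S(=O)(c1cc2ccccc2cn1)n1cc(C2=CCNCC2)c2ccccc21`: 12 nM
compound 2 `O=S(=O)(c1cccc2ncccc12)n1cc(C2=CCNCC2)c2cc(Cl)ccc21`: 11 nM
compound 3 `COc1ccc2c(c1)c(C1=CCNCC1)cn2S(=O)(=O)c1cccc2ncccc12`: 4 nM

Going by the values given here, compound 3 gives the lowest number of the three in this assay; compound 2 and compound 1 sit higher by steps beyond the scatter, and the only single-point step measured, a 2.8-fold lower number from compound 2 to compound 3 (0.44 log units; beyond the scatter), is a modest one. Compound 4 `COc1ccc2c(c1)c(C1=CCNCC1)cn2S(=O)(=O)c1cncc2ccccc12` differs from compound 3 by isoquinolin-4-yl in place of quinolin-5-yl on a sulfonyl sulfur. Among the compounds with values here, no measured pair isolates this exchange: compound 1 carries another isoquinolinyl but lacks the methoxy, so its value bears on it only loosely. The step in this assay from compound 3 to compound 4 is therefore expected to stay within the scatter, a 1.5-fold higher number from compound 3 to compound 4 (0.18 log units; within the scatter). Compound 4 is estimated at 6 nM, within 2 nM to 18 nM.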

Compound 4, inhibition constant: 3 nM
Compound 4: the middle estimate sits 2.0-fold (0.30 log units) above what was measured, and the stated range covers the measured number.
By their numbers in this assay, from the lowest: compounds 4 and 3 (each within the scatter of the next); then compounds 2 and 1 (each within the scatter of the next).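

In this assay, going by these compounds alone, the exchange of quinolin-5-yl for isoquinolin-4-yl on a sulfonyl sulfur gives a 1.3-fold lower number from compound 3 to compound 4 (0.12 log units; within the scatter) and so has a direct reading for the first time. Here the same atoms, joined differently, leave the number within the scatter, which compound 1 could not show, as it lacks the methoxy. Nothing given here accounts for this result.

Left open is how a plain phenyl or a naphthyl group on the sulfonyl sulfur would compare. Also open, going by these compounds, is whether the same exchange reads alike with chloro in place of the methoxy.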